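The compounds below may be only part of what the source reports. "The series", "measured", "known", "first", "only" and "open" are said of these compounds alone.

Two compounds share a fused two-ring core carrying a pyridyl group, and differ only in what sits on the aromatic nitrogen. In an assay on isolated protein for displacement of a labelled ligand from 5-hydroxytryptamine receptor 6 (Homo sapiens), read by scintillation counting, with a stated time of 1 h (on this read-out higher numbers stand for weaker inhibition and lower numbers for stronger inhibition), compound 1 `CS(=O)(=O)n1ccc2ccc(-c3ccncc3)cc21` gives 4050 nM, while compound 2 `CCCCS(=O)(=O)n1ccc2ccc(-c3ccncc3)cc21` gives 1150 nM. Going by the values given here, the only measured step, a 3.5-fold lower number from compound 1 to compound 2 (0.55 log units; beyond the scatter), shows that lengthening the chain on the sulfonyl group helps somewhat, and so compound 2 stands as the lower of the two numbers, with compound 1 the only comparator. Compound 3 `c1ccc(Cn2ccc3ccc(-c4ccncc4)cc32)cc1` goes further, with benzyl in place of butylsulfonyl on an aromatic nitrogen. Among the compounds with values here, no measured step covers the loss of the sulfonyl group itself, so the single step from compound 1 to compound 2 offers only weak guidance; the modest gain it showed cannot be assumed to carry over once the sulfonyl is gone. The step of a 1.7-fold higher number from compound 2 to compound 3 (0.24 log units; within the scatter) is therefore expected to be small, with a slight lean toward a higher number. Compound 3 is estimated at 2000 nM in this assay, within a range from 500 nM to 8000 nM.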

Compound 3, inhibition constant: 3260 nM
Compound 3: middle estimate off by 1.6-fold (0.21 log units), on the low side; the measured number falls inside the stated range.
By their numbers in this assay, from the lowest: compound 2; then compounds 3 and 1 (each within the scatter of the next).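

On an aromatic nitrogen of a five-membered aromatic ring, the sulfonyl group proves not to be needed for a measurable number in this assay: benzyl, with no sulfur and no hydrogen-bond acceptors, cannot be told apart from methylsulfonyl, with a 1.2-fold lower number from compound 1 to compound 3 (0.09 log units; within the scatter). Butylsulfonyl, which has the same count of heavy atoms as benzyl, does hold an edge, with a 2.8-fold higher number from compound 2 to compound 3 (0.45 log units; beyond the scatter), so at this position the advantage of compound 2 does not carry over to benzyl. Nothing available accounts for that difference.

The compounds shown leave open whether a longer chain on the sulfonyl would extend the gain seen with butylsulfonyl, and how phenylsulfonyl, which joins the sulfonyl to an aromatic ring, would compare. They also leave open what a plain hydrogen on this nitrogen, or an amine on the benzyl ring, would give.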